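Swapping an Aminophenyl for a Chlorothiazolyl on the Sulfonyl

The source may hold more compounds than are shown below. What is called first, only, known or untested is meant among the compounds shown, and "the series" means these compounds.

Compound 1 `CC1CCN(C2CCN(S(=O)(=O)c3cccc(N)c3)CC2)CC1` was tested in an ADME assay on HCT-116 cells (Homo sapiens) for cytotoxicity, read by CellTiter-Glo, with a stated time of 72 h; a lower number here means a stronger inhibitor, a higher number a weaker inhibitor. In this assay compound 1 gives > 5000 nM, which is a limit of the assay. Two related compounds were tested in the same way. Compound 2 `COc1ccccc1-c1cccc(S(=O)(=O)N2CCC(N3CCC(C)CC3)CC2)c1` gives > 5000 nM, again a limit. Compound 3 `CC1CCN(C2CCN(S(=O)(=O)c3cccc(-c4ccc(Cl)cc4)c3)CC2)CC1` gives > 5000 nM, also a limit. Because all three values sit at the same limit (the limit of > 5000 nM in this assay, at which 3 of the 3 values shown sit), the steps among them cannot be read: a step that the two limits leave unreadable from compound 1 to compound 2, a step that the two limits leave unreadable from compound 1 to compound 3 and a step that the two limits leave unreadable from compound 2 to compound 3. Compound 4 `Cc1nc(Cl)sc1S(=O)(=O)N1CCC(N2CCC(C)CC2)CC1` has not yet been measured. It differs from compound 1 at one place: 2-chloro-4-methyl-1,3-thiazol-5-yl in place of 3-aminophenyl on a sulfonyl sulfur. Within the data shown here, none of the measured steps touches the sulfonyl sulfur, and none has a readable size, so they give no guide to the direction or size of this step. All that the measured compounds show is that changes on an aromatic carbon of the shared core left the value at the limit. The expected step is a step that the limit leaves unreadable from compound 1 to compound 4. Compound 4 is estimated at 8000 nM, with a range from 2500 nM to 40000 nM, and the result is expected most likely to be reported as a limit once more.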

Compound 4, half-maximal inhibitory concentration: > 10000 nM
Compound 4: no number, only a limit; the forecaster's own chance of this, stated with the estimate: 80%; middle value at least 1.2-fold (0.09 log units) away from the limit.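

Compound 1 and compound 4 both stand at limits in this assay, so no new step can be read between them. The compounds shown leave open whether any change on the sulfonyl sulfur or an aromatic carbon of the shared core gives a measurable value.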